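Selenazole series: phenyl for methyl on the ring carbon

The source may hold more compounds than are shown below. What is called first, only, known or untested is meant among the compounds shown, and "the series" means these compounds.

Compound 1 `Cc1c[se]c(N/N=C/c2ccc(Cl)cc2)n1` and compound 2 `Clc1ccc(/C=N/Nc2nc(-c3ccccc3)c[se]2)cc1` share a core; compound 3 `CC(=O)N(C(=O)c1ccc(Cl)cc1)N(C(C)=O)c1nc(C)c[se]1` and compound 4 `CC(=O)N(C(=O)c1ccc(Cl)cc1)N(C(C)=O)c1nc(-c2ccccc2)c[se]1` share another, and the difference between the two cores is not broken down here. In a functional assay on HepG2 cells (Homo sapiens) for cytotoxicity, read by XTT assay, with a stated time of 72 h (on this read-out higher numbers stand for weaker inhibition and lower numbers for stronger inhibition), compound 1 gives 56500 nM and compound 2 gives 42500 nM. The change phenyl in place of methyl on an aromatic carbon made a 1.3-fold lower number from compound 1 to compound 2 (0.12 log units; within the scatter). In this assay compound 3 gives only the limit > 62700 nM, which is a limit of the assay and not a number. Compound 4 carries the same change, (phenyl in place of methyl on an aromatic carbon), at the same place. Since the earlier step stayed within the scatter, the expected step here is a step that the limit leaves unreadable from compound 3 to compound 4, most likely again ending at the limit (the limit of > 62700 nM in this assay, at which 1 of the 3 values shown sits). Compound 4 is therefore estimated at 65000 nM, between 30000 nM and 150000 nM.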

Compound 4, half-maximal inhibitory concentration: > 54200 nM
Compound 4: a limit, no number (the forecaster's own chance of this, stated with the estimate: 70%); the middle value does not contradict the limit.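

Compound 3 and compound 4 both stand only as limits of the assay, not as numbers, and the step between them cannot be read. As far as these compounds go, whether phenyl in place of methyl on an aromatic carbon changes the read-out on the core of compound 3 stays open.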